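The source may hold more compounds than are shown below. What is called first, only, known or untested is meant among the compounds shown, and "the series" means these compounds.

Compound 1 `C[C@H](Nc1ncnc2[nH]cnc12)c1cc2ccccn2c(=O)c1-c1ccccc1`: 93%
Compound 2 `Cc1cccc2cc([C@H](C)Nc3ncnc4[nH]cnc34)c(-c3ccccc3)c(=O)n12`: 73%
Compound 3 `Cc1c([C@H](C)Nc2nc(N)nc(N)c2C#N)c(-c2ccccc2)c(=O)n2cc(F)ccc12`: 85%

In an ADME assay on microsomes from liver (Rattus norvegicus), read by LC-MS, using NADPH, with a stated time of 30 min, tested at 1 uM (a higher number here means that more of the compound is left, a lower number that less of the compound is left), compound 3 stands second highest of the three numbers shown. Its nearest neighbour is compound 1, whose reading lies higher but within the scatter, so the two cannot be told apart; compound 2 lies lower than compound 3 by an amount beyond the scatter.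

Compound 4 `C[C@H](Nc1nc(N)nc(N)c1C#N)c1c(-c2ccccc2)c(=O)n2cc(F)ccc2c1-c1ccc(F)cc1` is not yet measured. It differs from compound 3 in one place: 4-fluorophenyl in place of methyl on an aromatic carbon.

Among the measured compounds shown here, only one step between measured compounds is available, and it concerns a different change on a different carbon of the core: a number 20 percentage points lower from compound 1 to compound 2 (beyond the scatter). That step shows that a small addition to the core can lower the remaining fraction by a modest amount. For the measured compounds named here, no measured pair shows what a 4-fluorophenyl does in place of a methyl, so the step to compound 4 has no direct precedent here.

Given this, the author expects a modest downward shift or none beyond the scatter, estimated as a number 11 percentage points lower from compound 3 to compound 4 (beyond the scatter). Compound 4 is therefore estimated to give 74% in this assay, with a range from 52% to 92%.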

Compound 4, percent of the compound remaining: 77%
Estimate against measurement, compound 4: 3 percentage points below; low and high end bracket the measured number.
By their numbers in this assay, from the lowest: compounds 2, 4, 3 and 1 (each within the scatter of the next, the first and the last beyond it).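

In this assay, the step of a number 8 percentage points lower from compound 3 to compound 4 (within the scatter) shows that on this aromatic carbon, ortho to a fused ring and two atoms from the ring nitrogen, 4-fluorophenyl can take the place of methyl without a change that can be told from the usual scatter. Among the compounds shown here, the earlier compounds could not show this: their only step, a number 20 percentage points lower from compound 1 to compound 2 (beyond the scatter) and beyond the scatter, concerns methyl in place of hydrogen on a different carbon of the core, so they said nothing about a larger group with its own aromatic ring at this position. Nothing measured here offers a reason for this reading.

The compounds shown leave open what an amine, a carboxylic acid or a plain phenyl would give on this carbon, and so whether the fluorine of the added ring has any part in the reading. They also leave open whether the same change would read alike on the other side of the molecule's variation, since it is seen only once, with the groups that compound 3 and compound 4 share.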